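The source may hold more compounds than are shown below. What is called first, only, known or untested is meant among the compounds shown, and "the series" means these compounds.

Measured so far in a physicochemical assay for solubility; a higher number here means a more soluble compound, a lower number a less soluble compound:
- Compound 1 `O=C(c1cccc(Cl)c1)N1CCC(NS(=O)(=O)c2cc(S(=O)(=O)c3ccccc3)ccc2C(F)(F)F)CC1`: 6300 nM
- Compound 2 `O=C(c1cccnc1)N1CCC(NS(=O)(=O)c2cc(S(=O)(=O)c3ccccc3)ccc2C(F)(F)F)CC1`: 50000 nM
- Compound 3 `O=C(O)c1cccc(S(=O)(=O)N2CCC(NS(=O)(=O)c3cc(S(=O)(=O)c4ccccc4)ccc3C(F)(F)F)CC2)c1`: 12500 nM

Two steps place compound 3 among these numbers: a 2.0-fold higher number from compound 1 to compound 3 (0.30 log units; within the scatter), and a 4.0-fold lower number from compound 2 to compound 3 (0.60 log units; beyond the scatter). Compound 4 `O=C(O)CCCC(=O)N1CCC(NS(=O)(=O)c2cc(S(=O)(=O)c3ccccc3)ccc2C(F)(F)F)CC1` keeps the shared core and carries (3-carboxypropyl)carbonyl in place of (3-carboxyphenyl)sulfonyl on an amine nitrogen in a ring. Both steps to compound 3 changed the group on that same nitrogen, but neither brings in the group now entering, so they offer only a rough guide. The two compounds with a carbonyl at this place are themselves far apart, with a 7.9-fold higher number from compound 1 to compound 2 (0.90 log units; beyond the scatter). Among the compounds with values here, no measured compound has a ring-free group there. A modest rise in this assay is therefore expected, no larger than the largest of these steps. The expected step is a 2.4-fold higher number from compound 3 to compound 4 (0.38 log units; beyond the scatter). Compound 4 is estimated at 30000 nM, with an expected range from 10000 nM to 90000 nM.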

Compound 4, solubility: 50000 nM
Beside the measured number, compound 4's estimate is 1.7-fold (0.22 log units) below it, and the stated range covers the measured number.
By their numbers in this assay, from the lowest: compounds 1 and 3 (each within the scatter of the next); then compounds 2 and 4 (each within the scatter of the next).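

In this assay, (3-carboxypropyl)carbonyl in place of (3-carboxyphenyl)sulfonyl on the amine nitrogen in the ring gives a 4.0-fold higher number from compound 3 to compound 4 (0.60 log units; beyond the scatter) and so brings this position up to the level seen for the pyridin-3-yl amide. On the carbonyl carbon, 3-carboxypropyl and pyridin-3-yl are level, with no change at the digits printed from compound 2 to compound 4 (within the scatter), while 3-carboxypropyl stands apart from 3-chlorophenyl, with a 7.9-fold higher number from compound 1 to compound 4 (0.90 log units; beyond the scatter), which shows that a group with no ring can reach the top of this small set. Nothing measured here explains these differences.

As far as these compounds go, it stays open whether a plain alkyl chain on the carbonyl would give the same number as 3-carboxypropyl, and how a longer chain or an amine at the chain end would compare. Also open, from the compounds shown here alone, is how a carboxylic acid on a chain would behave with a sulfonyl rather than a carbonyl on this nitrogen.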